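Swapping a pyridine for a fluorophenyl at the end of compound 3

The source may report more compounds than this note shows. Statements on the series, on what has been measured and on what is new or still open speak of the compounds shown alone.

Measured compounds:
- compound 1, `O=C([C@@H]1C[C@H]1c1ccccc1)N(CCNCC1CCCC1)c1ccc(-c2ccccc2)cc1`: 2.5 nM
- compound 2, `CC[C@H](C)[C@H](N)CN(C(=O)[C@@H]1C[C@H]1c1ccoc1)c1ccc(-c2ccccc2)cc1`: 580 nM
- compound 3, `CC(C)C[C@H](N)CN(C(=O)[C@@H]1C[C@H]1c1ccccc1)c1ccc(-c2ccncc2)cc1`: 13000 nM

In a functional assay for agonist activity at G protein-coupled receptor 88 (Homo sapiens), read by HTRF and cAMP accumulation (a lower number here means that less compound is needed, a higher number that more compound is needed for the effect), compound 3 stands highest of the three measured compounds, and its gaps to compound 2 and to compound 1 are both beyond the scatter. Compound 4, `CC(C)C[C@H](N)CN(C(=O)[C@@H]1C[C@H]1c1ccccc1)c1ccc(-c2ccc(F)cc2)cc1`, differs from compound 3 in one place: 4-fluorophenyl in place of pyridin-4-yl on an aromatic carbon. Among the compounds with values here, no measured pair shows this exact change, but the two compounds carrying a carbon-only outer ring, compound 1 at 2.5 nM and compound 2 at 580 nM, both sit far below compound 3. A step downward in this assay is therefore expected, about a 14-fold lower number from compound 3 to compound 4 (1.16 log units; beyond the scatter), though those compounds differ elsewhere too. Compound 4 is estimated at 900 nM, between 150 nM and 5000 nM.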

Compound 4, half-maximal effective concentration: 900 nM
For compound 4 middle estimate and measured number coincide at the digits printed; the range from low to high includes it.
By their numbers in this assay, from the lowest: compound 1; then compounds 2 and 4 (each within the scatter of the next); then compound 3.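

Within the data shown here, compounds 1 to 3 differ from one another in several places, so this pair gives the first direct reading of the outer ring: in this assay, 4-fluorophenyl in place of pyridin-4-yl gives a 14-fold lower number from compound 3 to compound 4 (1.16 log units; beyond the scatter) and counts as a large step. The swap removes the ring nitrogen and adds a fluorine together, so the two changes cannot be told apart. Nothing measured here explains the step. Still open, as far as these compounds go, is whether the step follows the lost nitrogen or the added fluorine, and how a plain phenyl, a chlorine or a methoxy group would read at this place.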